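The source may hold more compounds than are shown below. What is called first, only, known or untested is meant among the compounds shown, and "the series" means these compounds.

Compound 1, whose structure is `CC(O)(COc1cc(C(F)(F)F)cc(C(F)(F)F)c1)C(=O)Nc1ccc(C#N)cc1C(F)(F)F`, and compound 2, whose structure is `CC(O)(COc1cc(C(F)(F)F)cc(C(F)(F)F)c1)C(=O)Nc1ccc([N+](=O)[O-])cc1C(F)(F)F`, share one core and differ in a single group. In a functional assay on LNCaP cells (Homo sapiens) for antiproliferative activity, read by fluorescence and propidium iodide staining, with a stated time of 96 h (a lower number here means a stronger inhibitor, a higher number a weaker inhibitor), compound 1 gives 3560 nM, while compound 2 gives 24000 nM. The change between them is nitro in place of cyano on an aromatic carbon, and the step it made is a 6.7-fold higher number from compound 1 to compound 2 (0.83 log units; beyond the scatter). So on this core the exchange of a cyano group for a nitro group weakened the inhibitor by a modest but real amount.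

Compound 3, whose structure is `CC1(C)C(=O)N(c2ccc(C#N)c(C(F)(F)F)c2)C(=S)N1c1cc(C(F)(F)F)cc(C(F)(F)F)c1`, is built on a different core; the difference between the two cores is not broken down here. In this assay compound 3 is recorded as "nd(insoluble)" (no result reported), so there is no number and no anchor for it. Compound 4, whose structure is `CC1(C)C(=O)N(c2ccc([N+](=O)[O-])c(C(F)(F)F)c2)C(=S)N1c1cc(C(F)(F)F)cc(C(F)(F)F)c1`, has not yet been measured. It differs from compound 3 by nitro in place of cyano on an aromatic carbon. Within the data shown here, this is the same kind of change as the one from compound 1 to compound 2, not the same one: in compound 2 the nitro group stands meta to a trifluoromethyl group, whereas in compound 4 it stands ortho to a trifluoromethyl group, and the cores are not alike. With no value for compound 3, any expectation rests only on compound 1 and compound 2 and the step of a 6.7-fold higher number from compound 1 to compound 2 (0.83 log units; beyond the scatter), and it is a loose one. For compound 4 in this assay a value near 10000 nM is estimated, within a wide range from 1000 nM to 100000 nM.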

Compound 4, half-maximal inhibitory concentration: 9930 nM
The estimate for compound 4 lay 1.0-fold (0.00 log units) above the measured number, and the stated range covers the measured number.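

In this assay, among these compounds, compound 3 has no number, while compound 4 gives 9930 nM, so no step between compound 3 and compound 4 can be read. The compounds shown leave open whether nitro in place of cyano changes activity on this core as it did between compound 1 and compound 2. Nothing shown offers an explanation for the value of compound 4.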